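Swapping thiophen-2-yl for 4-methylbenzyl in compound 1

The source may hold more compounds than are shown below. What is called first, only, known or untested is meant among the compounds shown, and "the series" means these compounds.

- compound 1 `COc1ccc(S(=O)(=O)Oc2ccccc2/C=C(\C#N)C(=O)Nc2nnc(-c3cccs3)s2)cc1` gives 76%
- compound 2 `N#C/C(=C\c1ccccc1OS(=O)(=O)c1ccc([N+](=O)[O-])cc1)C(=O)Nc1nnc(-c2cccs2)s1` gives 40%
- compound 3 `N#C/C(=C\c1ccccc1OS(=O)(=O)c1ccc(Cl)cc1)C(=O)Nc1nnc(-c2cccc(F)c2)s1` gives 71%

All three numbers come from a functional assay on RS4-11 cells (Homo sapiens) for inhibition, read by CCK-8 assay, with a stated time of 48 h, tested at 20 uM (on this read-out lower numbers stand for less inhibition of growth and higher numbers for more inhibition of growth at the one concentration tested), and compound 1 shares the top of them with compound 3, the two lying within the scatter of each other. Compound 4 `COc1ccc(S(=O)(=O)Oc2ccccc2/C=C(\C#N)C(=O)Nc2nnc(Cc3ccc(C)cc3)s2)cc1` keeps the core of compound 1 and changes one group: 4-methylbenzyl in place of thiophen-2-yl on an aromatic carbon In words, 4-methylbenzyl takes the place of thiophen-2-yl on an aromatic carbon.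

Among the compounds with values here, no measured step tests this place alone. Compound 3 differs from compound 1 in more than one place, so it cannot isolate the swap. Within the data shown here, the only measured step, a number 36 percentage points lower from compound 1 to compound 2 (beyond the scatter), is a nitro in place of methoxy elsewhere in the molecule. It bears only indirectly, showing that one swap can move the number a long way, so a wide range is fair. A moderate fall is expected in this assay, though no change beyond the scatter remains possible. The estimate is a number 16 percentage points lower from compound 1 to compound 4 (beyond the scatter) and stays uncertain. For compound 4 the expected value is 60%, with an estimated range from 35% to 82%.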

Compound 4, percent growth inhibition at one concentration: 79%
Compound 4: the middle estimate sits 19 percentage points below what was measured; measured number inside the range.
By their numbers in this assay, from the lowest: compound 2; then compounds 3, 1 and 4 (each within the scatter of the next).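

In this assay, putting 4-methylbenzyl in place of thiophen-2-yl gives a number 3 percentage points higher from compound 1 to compound 4 (within the scatter). This position on the shared core therefore tolerates a swap from a five-membered aromatic ring with one hetero atom to a six-membered aromatic ring of carbon only, with more heavy atoms in the group, and growth inhibition at the one concentration tested is not lost. The thiophen-2-yl group is thus not required for this level of inhibition in these cells, and nothing measured here explains why the swap makes so little difference.

From the compounds shown here alone, whether this position would equally tolerate an amine, a carboxylic acid or a longer chain remains open. A reading at one concentration also leaves open whether compound 1 and compound 4 would separate at lower concentrations.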